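The source may report more compounds than this note shows. Statements on the series, on what has been measured and on what is new or still open speak of the compounds shown alone.

Measured in a functional assay on V79 cells (Cricetulus griseus) for cytotoxicity, read by colony formation; a lower number here means a stronger inhibitor, a higher number a weaker inhibitor:
compound 1 `CCNCC1CCN(c2c(F)cc3c(=O)c(C(=O)O)cn(C4CC4)c3c2Cl)C1`: 11 ug/mL; 11 ug/mL; < 11 ug/mL (3 entries)
compound 2 `NC1CCCN(c2c(F)cc3c(=O)c(C(=O)O)cn(C4CC4)c3c2F)C1`: 53 ug/mL

Going by the values given here, compound 2 gives 53 ug/mL, the only single number in this small set. The record for compound 1 is the several entries of compound 1 in this assay, 11 ug/mL; 11 ug/mL; < 11 ug/mL (3 entries), and one of those entries is a limit of the assay and not a number.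

Compound 3 `NC1CCCN(c2c(F)cc3c(=O)c(C(=O)O)cn(C4CC4)c3c2Cl)C1` keeps the structure of compound 2 apart from one change: chloro in place of fluoro on an aromatic carbon. This is chloro in place of fluoro on an aromatic carbon, ortho to a 3-aminopiperidin-1-yl group. Among the compounds with values here, no measured pair in this assay shows this swap on its own, so the size of the step can only be expected, not read off. Compound 1 also carries a chloro group and reads 11 ug/mL; 11 ug/mL; < 11 ug/mL (3 entries), so a modest move toward a lower number, meaning a stronger inhibitor, is expected. Compound 1 is only a loose guide. It differs from compound 3 elsewhere as well. The estimated 1.9-fold lower number from compound 2 to compound 3 (0.28 log units; within the scatter) is therefore moderate. For compound 3 the expected value is 28 ug/mL, with an estimated range of 10 ug/mL to 70 ug/mL.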

Compound 3, half-maximal inhibitory concentration: 24 ug/mL
Beside the measured number, compound 3's estimate is 1.2-fold (0.07 log units) above it, and the stated range covers the measured number.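

In this assay, going by these compounds alone, the exchange of chloro for fluoro on an aromatic carbon, ortho to a 3-aminopiperidin-1-yl group, gives a 2.2-fold lower number from compound 2 to compound 3 (0.34 log units; beyond the scatter) and is the first step in this set that can be read on its own. With everything else in compound 2 kept, the swap of one halogen atom for another is enough to shift the reading, so this position does respond to which of the two atoms it carries, although the step is modest and rests on a single pair. Compound 1 is the other compound with chloro at this carbon, but it differs from compound 3 elsewhere as well, so it cannot confirm the step, and one of its entries is a limit of the assay and not a number: the several entries of compound 1 in this assay, 11 ug/mL; 11 ug/mL; < 11 ug/mL (3 entries).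

As far as these compounds go, whether the same direction would hold for a bromo, methoxy or nitrile group on this carbon remains open. Also open, from the compounds shown here alone, is whether the chloro-for-fluoro step would keep its size with a different amine, such as a piperazine, in place of the 3-aminopiperidin-1-yl group, and the pair alone gives no explanation for the shift.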